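Flipping a Single Ring Stereocentre on a Piperazine Acid

The source may report more compounds than this note shows. Statements on the series, on what has been measured and on what is new or still open speak of the compounds shown alone.

Measured so far:
Compound 1 `CCCCCN(CCCCC)C(=O)N1CCN(C(=O)N(c2ccccc2)c2ccccc2)[C@H](C(=O)O)C1` gives 130 nM in an assay on CHO cells for binding affinity to Substance-P receptor (Homo sapiens); on this read-out higher numbers stand for weaker inhibition and lower numbers for stronger inhibition.
Compound 2 `CCCCCN(CCCCC)C(=O)N1CCN(C(=O)N(c2ccccc2)c2ccccc2)[C@H](C(=O)N(C)CCN(C)C)C1` gives 930 nM in this assay.

Among these two numbers compound 1 has the lower one, meaning the stronger inhibition, and its nearest neighbour is compound 2: the step of a 7.2-fold higher number from compound 1 to compound 2 (0.85 log units; beyond the scatter) came with the exchange of the hydroxy group of the carboxylic acid for the (2-(dimethylamino)ethyl)(methyl)amino group. Compound 3 `CCCCCN(CCCCC)C(=O)N1CCN(C(=O)N(c2ccccc2)c2ccccc2)[C@@H](C(=O)O)C1` keeps everything of compound 1 except the drawn configuration: the two compounds have the same atoms and bonds and differ only in configuration as drawn: 1 of 1 stereo elements differ; a stereocentre at a saturated ring carbon is drawn S in compound 1 and R in compound 3. Among the compounds with values here, no measured step touches that kind of change, since the one step available swaps a group at the carbonyl carbon and leaves the stereocentre alone. Within the data shown here, the only guidance is therefore general: mirror-image partners of this kind often differ markedly in this assay, and the unknown is in which direction and by how much. With compound 1 as the anchor, compound 3 is expected to sit at 500 nM, within the range 100 nM to 4000 nM; the expected step of a 3.8-fold higher number from compound 1 to compound 3 (0.59 log units; beyond the scatter) is deliberately left wide and leans toward weaker inhibition.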

Compound 3, half-maximal inhibitory concentration: 3000 nM
Estimate against measurement, compound 3: 6.0-fold (0.78 log units) below; the measured number falls inside the stated range.
By their numbers in this assay, from the lowest: compound 1; then compound 2; then compound 3.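

This result shows that the position responds to spatial arrangement and not only to which group sits there: in this assay turning the ring stereocentre from S to R gives a 23-fold higher number from compound 1 to compound 3 (1.36 log units; beyond the scatter) with all atoms and bonds unchanged. The earlier step (a 7.2-fold higher number from compound 1 to compound 2 (0.85 log units; beyond the scatter)) exchanged the hydroxy group on the carbonyl carbon and left the stereocentre alone, so it could say nothing on this point, and it is the smaller of the two steps, which means that among these compounds the drawn configuration weighs more than that exchange of group. The gap can be pinned on this single stereocentre, with S the form giving the stronger inhibition, because nothing else separates the pair: the fact that compounds 1 and 3 differ only in the configuration as drawn.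

Going by these compounds, whether the preference for S survives once the acid is replaced remains open, as the (2-(dimethylamino)ethyl)(methyl)amino amide appears here in the S form alone. Equally open, on these data alone, is how a methyl ester or a primary amide in place of the carboxylic acid would fare in either configuration.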